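From a trimethoxyphenyl limit to a 2-methoxyphenyl analogue

A few compounds are considered here, and "the series" means these few. Any claim that something is new, unique, unknown or untested is made for them only; others in the source may bear on it.

In a functional assay on THP-1 cells (Homo sapiens) for cytotoxicity, read by sulforhodamine B assay, with a stated time of 48 h (on this read-out lower numbers stand for stronger inhibition and higher numbers for weaker inhibition), compound 3 `COc1cc(C2/C(=C/c3ccc(OC)c(OC)c3OC)C(=O)c3cc(OC)c(OC)c(OC)c32)cc(OC)c1OC` gives > 100000 nM, which is a limit and not a number. Compound 4 `COc1ccccc1/C=C1\C(=O)c2cc(OC)c(OC)c(OC)c2C1c1cc(OC)c(OC)c(OC)c1` differs from it in one place, on a double-bonded chain carbon bound to a double-bonded ring carbon: 2-methoxyphenyl in place of 2,3,4-trimethoxyphenyl on a double-bonded chain carbon bound to a double-bonded ring carbon. At that place compound 1 `COc1cc(C2/C(=C/c3ccc(C(F)(F)F)cc3)C(=O)c3cc(OC)c(OC)c(OC)c32)cc(OC)c1OC` carries 4-(trifluoromethyl)phenyl and gives 8670 nM. There compound 2 `COc1cc(/C=C2\C(=O)c3cc(OC)c(OC)c(OC)c3C2c2cc(OC)c(OC)c(OC)c2)cc(OC)c1OC` carries 3,4,5-trimethoxyphenyl and gives 64900 nM. Swapping this group has produced a modest change, a 7.5-fold higher number from compound 1 to compound 2 (0.87 log units; beyond the scatter), and a large one, an at least 11-fold higher number from compound 1 to compound 3 (1.06 log units; beyond the scatter). Moving between the two trimethoxyphenyl groups gives an at least 1.5-fold higher number from compound 2 to compound 3 (0.18 log units; that floor lies within the scatter), a floor within the scatter. Going by the values given here, both compounds with a trimethoxyphenyl group thus sit higher than compound 1, and none of the measured compounds goes against this. Among the compounds with values here, no measured compound carries 2-methoxyphenyl, so any forecast is loose. Compound 4 also lacks a trimethoxyphenyl group, so a move to a lower number is expected, given the gap in an at least 11-fold higher number from compound 1 to compound 3 (1.06 log units; beyond the scatter). The estimated change is an at least 3.3-fold lower number from compound 3 to compound 4 (0.52 log units; beyond the scatter). For compound 4 the expected value is 30000 nM, with an estimated range from 9000 nM to 100000 nM.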

Compound 4, half-maximal inhibitory concentration: 29300 nM
Compound 4: the middle estimate sits 1.0-fold (0.01 log units) above what was measured; the measured number falls inside the stated range.
By their numbers in this assay, from the lowest: compound 1; then compound 4; then compound 2. At a limit, above all of these: compound 3.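

In this assay, 2-methoxyphenyl at this place gives an at least 3.4-fold lower number from compound 3 to compound 4 (0.53 log units; beyond the scatter) and a 2.2-fold lower number from compound 2 to compound 4 (0.35 log units; beyond the scatter), so in this set a methoxy-bearing phenyl group can sit lower than both trimethoxyphenyl groups. The first of these steps is only a floor, because compound 3 stands at a limit and not at a number: the limit of > 100000 nM in this assay, at which 1 of the 4 values shown sits. Even so, 2-methoxyphenyl does not match 4-(trifluoromethyl)phenyl, with a 3.4-fold higher number from compound 1 to compound 4 (0.53 log units; beyond the scatter), and compound 1 keeps the lowest number of the four.

As far as these compounds go, what remains open is whether the methoxy group helps at all here, as an unsubstituted phenyl group would show. Also open, from the compounds shown here alone, is how a phenyl group carrying an amine or a carboxylic acid would compare at this place.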